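Trimming one methoxy from compound 3

This account rests on a few compounds, and the source may have more. Where it says the series, first, only, none or still open, it means among the compounds named here.

Compound 1 `COc1cc(/C(=C\c2cn(C(C)=O)c3ccc(OCc4ccccc4)cc23)C(=O)O)cc(OC)c1OC`, compound 2 `COc1ccc(OC)c(/C(=C\c2cn(C(C)=O)c3ccc(OCc4ccccc4)cc23)C(=O)O)c1` and compound 3 `COc1ccc(/C(=C\c2cn(C(C)=O)c3ccc(OCc4ccccc4)cc23)C(=O)O)cc1OC` share one core and differ only in their methoxy pattern. In a functional assay on A549 cells (Homo sapiens) for cytotoxicity, read by MTT assay, with a stated time of 72 h (a lower number here means a stronger inhibitor, a higher number a weaker inhibitor), compound 1 gives 89100 nM, compound 2 gives 54500 nM and compound 3 gives 54800 nM; all three sit within the scatter of one another, so compound 3 holds no separable place among them. Compound 4 `COc1ccc(/C(=C\c2cn(C(C)=O)c3ccc(OCc4ccccc4)cc23)C(=O)O)cc1` is reached from compound 3 by hydrogen in place of methoxy on an aromatic carbon. Among the measured compounds shown here, the steps that bear on this are a 1.6-fold lower number from compound 1 to compound 3 (0.21 log units; within the scatter), the same kind of change, and a 1.0-fold higher number from compound 2 to compound 3 (0.00 log units; within the scatter), a shift of methoxy pattern; neither moved this assay beyond the scatter. The expected step in this assay is therefore a 1.0-fold higher number from compound 3 to compound 4 (0.00 log units; within the scatter), nothing beyond the scatter. Compound 4 is estimated at 55000 nM, within 25000 nM to 120000 nM.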

Compound 4, half-maximal inhibitory concentration: > 100000 nM
Compound 4: a limit, no number; the forecaster's own chance of this, stated with the estimate: 10%; at least 1.8-fold (0.25 log units) between middle value and limit.
By their numbers in this assay, from the lowest: compounds 2, 3 and 1 (each within the scatter of the next). At a limit, above all of these: compound 4.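

Compound 4, with the 4-methoxyphenyl group, is the only compound shown that reaches a limit rather than a number: the limit of > 100000 nM in this assay, at which 1 of the 4 values shown sits.
Its steps therefore give only floors, and none of them separates it from the dimethoxy or trimethoxy compounds (an at least 1.8-fold higher number from compound 3 to compound 4 (0.26 log units; that floor lies within the scatter); an at least 1.8-fold higher number from compound 2 to compound 4 (0.26 log units; that floor lies within the scatter); an at least 1.1-fold higher number from compound 1 to compound 4 (0.05 log units; that floor lies within the scatter)).
So removing this methoxy is not shown to weaken the compound, though no gain in this assay appears either.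

As far as these compounds go, how far compound 4 lies beyond its limit remains open. Also open, from the compounds shown here alone, is how a hydroxyl or an amine would read on this aromatic carbon.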